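The compounds below may be only part of what the source reports. "The series", "measured", "known", "first", "only" and "open" are said of these compounds alone.

Compound 1 `CS(=O)(=O)c1ccc(C(=O)N2CCC(C(=O)N3CCN(c4ccc(F)cc4)CC3)CC2)cc1[N+](=O)[O-]`: in an assay on isolated protein for inhibition of thyroid hormone receptor alpha (Homo sapiens), read by fluorescence polarization (a lower number here means a stronger inhibitor, a higher number a weaker inhibitor), compound 1 gives > 60000 nM, which is a limit of the assay.
Compound 2 `CC(C)N(C(=O)CNC(=O)c1ccc(S(C)(=O)=O)c([N+](=O)[O-])c1)C(C)C`: in this assay compound 2 gives > 60000 nM, again a limit.
Compound 3 `CN(CC(=O)N1CCN(c2ccccc2)CC1)C(=O)c1ccc(S(C)(=O)=O)c([N+](=O)[O-])c1`: in this assay compound 3 gives > 60000 nM, again a limit.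

Of the compounds shown here, three built on the same shared core have been measured, and none of them gives a number. Compound 2 therefore stands at the limit of the assay, and it stands there together with all the others, as shown by the limit of > 60000 nM in this assay, at which 3 of the 3 values shown sit. Among the measured compounds shown here, no two measured compounds differ in one place only, so no single step has been determined, and nothing can be said about what any change to the core does.

Compound 4 `CN1CCN(C(=O)CNC(=O)c2ccc(S(C)(=O)=O)c([N+](=O)[O-])c2)CC1` is the one still to be measured. It differs from compound 2 in a single place: 4-methylpiperazin-1-yl in place of diisopropylamino on a carbonyl carbon. For the measured compounds named here, with every measured value a limit, there is no measured step to lean on, and the expected step in this assay from compound 2 to compound 4 is estimated as none that would be seen beyond the scatter, most likely a limit again, a step that the limit leaves unreadable from compound 2 to compound 4. For compound 4 the estimate in this assay is 80000 nM, with a range from 30000 nM to 300000 nM.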

Compound 4, half-maximal inhibitory concentration: > 60000 nM
Compound 4 was reported as a limit; the forecaster's own chance of this, stated with the estimate: 85%; the middle value is on the limit's open side.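

In this assay, compound 2 and compound 4 are both reported only as limits, so no step can be read for 4-methylpiperazin-1-yl in place of diisopropylamino on a carbonyl carbon. All compounds shown sit at the same limit: the limit of > 60000 nM in this assay, at which 4 of the 4 values shown sit. Going by these compounds, what remains open is whether any change to the shared core would give a measurable value in this assay.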